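A Ring Exchange on the Sulfonyl Sulfur

A few compounds are considered here, and "the series" means these few. Any claim that something is new, unique, unknown or untested is made for them only; others in the source may bear on it.

Three compounds sharing one core have entries so far in an ADME assay on Vero cells (Homo sapiens) for cytotoxicity against Vero (Chlorocebus sabaeus), read by MTT assay (on this read-out higher numbers stand for lower toxicity in this test and lower numbers for higher toxicity in this test), for comparison. For compound 1 `O=S(=O)(Nc1cccc2cccnc12)c1ccc(F)cc1` the entry reads "not determined" (no result reported) and offers no number. Compound 2 `O=S(=O)(Nc1cccc2cccnc12)c1ccc(-c2ccccc2)cc1` gives 245000 nM while compound 3 `O=S(=O)(Nc1cccc2cccnc12)c1ccc(Br)cc1` gives 88700 nM and so holds the lower of the two numbers, which marks it as the more toxic of the pair.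

Compound 4 `O=S(=O)(Nc1cccc2cccnc12)c1cc(Br)c(Br)s1` has not yet been measured. Going by the values given here, it keeps the core but carries 4,5-dibromothiophen-2-yl in place of 4-bromophenyl on a sulfonyl sulfur as its single change.

Among the compounds with values here, only one measured step offers any guide: a 2.8-fold lower number from compound 2 to compound 3 (0.44 log units; beyond the scatter) with bromo in place of phenyl on an aromatic carbon. That step is modest, though beyond the scatter, and it is a different exchange from this one. Within the data shown here, no measured compound carries a five-membered aromatic ring with 1 hetero atom, so the guide is loose. Going by the modest size of a 2.8-fold lower number from compound 2 to compound 3 (0.44 log units; beyond the scatter) a step of similar size, leaning weakly downward, is expected in this assay for this exchange. The estimated change is a 1.4-fold lower number from compound 3 to compound 4 (0.14 log units; within the scatter) and its direction remains uncertain. For compound 4 the estimated value is 65000 nM within a range of 22000 nM to 190000 nM at this stage.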

Compound 4, half-maximal cytotoxic concentration: 68700 nM
Estimate against measurement, compound 4: 1.1-fold (0.02 log units) below; measured number inside the range.
By their numbers in this assay, from the lowest: compounds 4 and 3 (each within the scatter of the next); then compound 2.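

On the sulfonyl sulfur, putting 4,5-dibromothiophen-2-yl in place of 4-bromophenyl swaps a six-membered aromatic ring of carbon only for a five-membered aromatic ring with 1 hetero atom, while the count of 7 heavy atoms stays the same. In this assay this exchange gives a 1.3-fold lower number from compound 3 to compound 4 (0.11 log units; within the scatter), so the ring attached to the sulfur was replaced outright, not just its substituent as in the earlier step, and the two compounds cannot be told apart in this test. Nothing measured here offers an explanation for this result.

The exchange alters the ring and the number of bromine atoms in one move, so the compounds shown cannot separate what each change contributes, and compound 1, with no number, adds nothing to the comparison. On these data alone, what also stays open is how this test would respond to a more different group on the five-membered ring, such as an amine or a carboxylic acid in place of a bromine.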